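The source may hold more compounds than are shown below. What is called first, only, known or untested is meant among the compounds shown, and "the series" means these compounds.

Two compounds share a core in which a lactone is linked through a double bond to a dichlorinated aromatic ring carrying a second aromatic ring. Compound 1 `COc1ccc(-c2cc(Cl)cc(Cl)c2/C=C/[C@@H]2C[C@@H](O)CC(=O)O2)cc1` bears a 4-methoxyphenyl group and in an assay for inhibition of 3-hydroxy-3-methylglutaryl-coenzyme A reductase (Rattus norvegicus) (a lower number here means a stronger inhibitor, a higher number a weaker inhibitor), compound 1 gives 470 nM. Compound 2 `COc1cccc(-c2cc(Cl)cc(Cl)c2/C=C/[C@@H]2C[C@@H](O)CC(=O)O2)c1` bears a 3-methoxyphenyl group instead, and in this assay compound 2 gives 50 nM, the lowest of the two numbers; the step of a 9.4-fold lower number from compound 1 to compound 2 (0.97 log units; beyond the scatter) is beyond the scatter. Compound 3 `O=C1C[C@H](O)C[C@@H](/C=C/c2c(Cl)cc(Cl)cc2-c2ccc(Cl)c(Cl)c2)O1` differs from compound 2 by 3,4-dichlorophenyl in place of 3-methoxyphenyl on an aromatic carbon. Among the measured compounds shown here, no measured step touches this kind of change: the only step seen moves a methoxy group from one position to another on the same ring, and says nothing about exchanging methoxy for chlorine. The expectation for compound 3 therefore rests on compound 2 alone, with a wide range and no clear direction, so the step of a 1.6-fold higher number from compound 2 to compound 3 (0.20 log units; within the scatter) is expected to stay small. Compound 3 is estimated at 80 nM in this assay, within 15 nM to 400 nM.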

Compound 3, half-maximal inhibitory concentration: 25 nM
Beside the measured number, compound 3's estimate is 3.2-fold (0.51 log units) above it; measured number inside the range.
By their numbers in this assay, from the lowest: compounds 3 and 2 (each within the scatter of the next); then compound 1.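

In this assay, exchanging the 3-methoxyphenyl group for 3,4-dichlorophenyl gives a 2.0-fold lower number from compound 2 to compound 3 (0.30 log units; within the scatter), so this position accepts a ring with two chlorines and no oxygen without a change that stands out from the scatter. The 3,4-dichlorophenyl ring also carries a chlorine where the 4-methoxyphenyl ring carries its methoxy, yet the exchange gives a 19-fold lower number from compound 1 to compound 3 (1.27 log units; beyond the scatter), so among these three compounds a group in that place does not by itself go with the higher number.

As far as these compounds go, whether an amine or a carboxylic acid on this ring would keep the number as low as in compound 2 and compound 3 stays open. Nothing measured here bears on why these steps have the sizes they do.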